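The source may hold more compounds than are shown below. What is called first, only, known or untested is meant among the compounds shown, and "the series" means these compounds.

Measured compounds:
Compound 1, `COC(=O)c1c(NC(=O)N2CCN(C)CC2)sc2c1CCC2`, in an assay on cells for agonist activity at Toll-like receptor 2 (Homo sapiens), with a stated time of 24 h (on this read-out lower numbers stand for an effect already at smaller amounts and higher numbers for an effect only at larger amounts of compound), gives 450 nM.
Compound 2, `CC(C)OC(=O)c1c(NC(=S)N2CCN(C)CC2)sc2c1CCC2`, in this assay gives 16400 nM.
Compound 3, `CC(C)OC(=O)c1c(NC(=S)N2CCNCC2)sc2c1CCC2`, in this assay is reported as "not active" (no number reported).

Among these three, only compound 1 and compound 2 carry a number in this assay; compound 3 stands apart from them with no number at all, reported simply as showing no effect. Compound 4, `CC(=O)N1CCN(C(=S)Nc2sc3c(c2C(=O)OC(C)C)CCC3)CC1`, has not yet been measured in this assay. It differs from compound 3 in one place: acetyl in place of hydrogen on an amine nitrogen in a ring. For the measured compounds named here, no measured pair of compounds tells how this particular change plays out, so the size of the step from compound 3 to compound 4 in this assay is not known from the data. Given that compound 3 gave no effect and that compound 2 gave only 16400 nM, compound 4 is expected to be weak at best, and a fair chance remains that it too yields no number. For compound 4 the estimate in this assay is 30000 nM, with a range from 8000 nM to 150000 nM.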

Compound 4, half-maximal effective concentration: "not active" (no number reported)
Nothing numeric was reported for compound 4, and the estimate cannot be compared.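

In this assay compound 3 and compound 4 are both reported as not active, so no step can be read between them, and no evidence bears on this result. The compounds shown leave open what acetyl in place of hydrogen does where a number can be measured.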